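Replacing a bromine with a larger ring-bearing group

The compounds below may be only part of what the source reports. "The series", "measured", "known", "first", "only" and "open" are said of these compounds alone.

In an ADME assay on HepG2 cells (Homo sapiens) for cytotoxicity, read by luminescence, with a stated time of 72 h (on this read-out lower numbers stand for an effect already at smaller amounts and higher numbers for an effect only at larger amounts of compound), compound 1 `CCOC(=O)c1c(-c2cccc(Br)c2)[nH]c2cc(OC)ccc2c1=O` gives > 21500 nM as a limit, not a number. Compound 2 `CCOC(=O)c1c(-c2cccc(Cl)c2)[nH]c2cc(OC)c(F)cc2c1=O` gives > 21500 nM as a limit too. Compound 3 `CCOC(=O)c1c(-c2cccc(Br)c2)[nH]c2cc(OC)c(F)cc2c1=O` gives > 21500 nM as a limit also. Compound 4 `CCOC(=O)c1c(-c2cccc(Cc3nc(C)c(C)s3)c2)[nH]c2cc(OC)c(F)cc2c1=O` replaces the bromine of compound 3 on an aromatic carbon (a group of 8 heavy atoms (6 carbon, 1 nitrogen, 1 sulfur; one five-membered aromatic ring with 2 hetero atoms) in place of one bromine atom, on an aromatic carbon), bringing in one five-membered aromatic ring with 2 hetero atoms. The measured changes give no size: there is a step that the two limits leave unreadable from compound 1 to compound 3 for fluoro in place of hydrogen, and a step that the two limits leave unreadable from compound 2 to compound 3 for bromo in place of chloro. With compound 3 held at a limit (the limit of > 21500 nM in this assay, at which 3 of the 3 values shown sit), no step beyond the usual scatter is expected. The estimated step is an at least 1.0-fold lower number from compound 3 to compound 4 (0.03 log units; that floor lies within the scatter) and no firm direction is expected. For compound 4 the estimated value is 20000 nM with an expected range from 7000 nM to 45000 nM in this read-out.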

Compound 4, half-maximal effective concentration: > 21500 nM
Compound 4: a limit, no number; the forecaster's own chance of this, stated with the estimate: 65%; middle value at least 1.0-fold (0.03 log units) from the limit.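

Compound 4 also gives only a limit, so its steps from compound 3 and from compound 2 cannot be read: the limit of > 21500 nM in this assay, at which 4 of the 4 values shown sit. Going by these compounds, the amount at which compound 1 to compound 4 would actually reach half-maximal effect stays open, and with it whether the swap changes anything.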